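Chloro for hydrogen on two related phenyl-thiadiazole series

This account rests on a few compounds, and the source may have more. Where it says the series, first, only, none or still open, it means among the compounds named here.

Half-maximal inhibitory concentrations in a functional assay on MCF7 cells (Homo sapiens) for cytotoxicity, read by sulforhodamine B assay, with a stated time of 48 h (on this read-out lower numbers stand for stronger inhibition and higher numbers for weaker inhibition), so far:
compound 1, `c1ccc(-c2nnc(Nc3ncnc4ccccc34)s2)cc1`: 3.61 ug/mL
compound 2, `Clc1ccc(-c2nnc(Nc3ncnc4ccccc34)s2)cc1`: 2.04 ug/mL
compound 3, `O=S1(=O)N=C(Nc2nnc(-c3ccccc3)s2)c2ccccc21`: 2.92 ug/mL

Compound 1 and compound 2 share one core and differ by a single change, (chloro in place of hydrogen on an aromatic carbon). That change gave a 1.8-fold lower number from compound 1 to compound 2 (0.25 log units; within the scatter), so the two values cannot be ordered with confidence. Compound 3 carries a different core; the difference between the core of compound 1 and the core of compound 3 is not broken down here. Its value in this assay lies within the scatter of both compound 1 and compound 2, so no ranking among the three measured compounds is supported.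

Compound 4, `O=S1(=O)N=C(Nc2nnc(-c3ccc(Cl)cc3)s2)c2ccccc21`, has not yet been measured. It relates to compound 3 as compound 2 relates to compound 1: chloro in place of hydrogen on an aromatic carbon. The surroundings of the place are described in the same words for both pairs, so this is the same change on a second core. For the measured compounds named here, the only measured instance of it is small, and on that basis the step from compound 3 to compound 4 is expected to be of similar size, a 1.7-fold lower number from compound 3 to compound 4 (0.23 log units; within the scatter), because the earlier instance gave a 1.8-fold lower number from compound 1 to compound 2 (0.25 log units; within the scatter). Compound 4 is therefore estimated at 1.7 ug/mL in this assay, with a plausible range from 0.9 ug/mL to 3.3 ug/mL.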

Compound 4, half-maximal inhibitory concentration: 2.92 ug/mL
The estimate for compound 4 lay 1.7-fold (0.23 log units) below the measured number, and the stated range covers the measured number.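

In this assay, chloro in place of hydrogen on an aromatic carbon of the second core gave no change at the digits printed from compound 3 to compound 4 (within the scatter). Set beside the first core, the two steps do not differ beyond what repeated measurement would allow: the same change on two cores in this assay, a 1.8-fold lower number (0.25 log units; within the scatter) from compound 1 to compound 2 and no change at the digits printed (within the scatter) from compound 3 to compound 4, 1.8-fold (0.25 log units) apart, within the scatter of two such steps. This shows only that phenyl to 4-chlorophenyl gave no step beyond the scatter on either core, so the two pairs agree, but it does not show that chloro has a real effect on either core or that a step of any particular size carries from one core to the other.

Still open, on these data alone, is whether another group at the same place, such as methoxy, an amine or a carboxylic acid, would give a step beyond the scatter on either core. If one did, the pairs would first offer a real test of whether a change carries between these two cores.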